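The source may hold more compounds than are shown below. What is called first, only, known or untested is meant among the compounds shown, and "the series" means these compounds.

Measured in an assay on cells for inhibition of Amine oxidase [flavin-containing] A (Homo sapiens), read by fluorescence, spectrophotometry and Amplex Red, with stated times of 60 min and 30 min; a higher number here means a weaker inhibitor, a lower number a stronger inhibitor:
compound 1 `CN(C)CCC(=O)c1cc2ccc(O)cc2oc1=O` gives 110000 nM.
compound 2 `O=C(CCN1CCCCC1)c1cc2ccc(O)cc2oc1=O` gives > 200000 nM, which is a limit of the assay and not a number.
compound 3 `COc1ccc2cc(C(=O)CCN(C)C)c(=O)oc2c1` gives 7630 nM.

Among the values that are numbers, compound 1 stands highest: compound 3 lies far below it, and compound 2 is known only as a limit. Compound 4 `Cc1cc(O)cc2oc(=O)c(C(=O)CCN(C)C)cc12` differs from compound 1 by methyl in place of hydrogen on an aromatic carbon.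

Two measured steps start from compound 1. Exchanging the dimethylamino group on the chain for piperidin-1-yl gives an at least 1.8-fold higher number from compound 1 to compound 2 (0.25 log units; that floor lies within the scatter), a step known only through (the limit of > 200000 nM in this assay, at which 1 of the 3 values shown sits). Putting a methyl on the hydroxy oxygen gives a 14-fold lower number from compound 1 to compound 3 (1.16 log units; beyond the scatter). Neither step touches a carbon of the aromatic ring, so neither bears directly on the change to compound 4. The step to compound 3 shows that a single methyl can move the number a great deal, but that methyl sits on oxygen and removes the hydroxy donor, whereas in compound 4 the hydroxy group stays and the methyl enters on ring carbon. With no direct guide, a step no larger than the scatter, perhaps a slight lowering, is expected in this assay, giving a 1.8-fold lower number from compound 1 to compound 4 (0.26 log units; within the scatter).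

Compound 4 is therefore estimated at 60000 nM, within a range from 15000 nM to 200000 nM.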

Compound 4, half-maximal inhibitory concentration: > 200000 nM
Compound 4 was reported as a limit (the forecaster's own chance of this, stated with the estimate: 15%); at least 3.3-fold (0.52 log units) between middle value and limit.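

A methyl on this aromatic carbon, ortho to a fused ring and meta to a hydroxy group, gives an at least 1.8-fold higher number from compound 1 to compound 4 (0.25 log units; that floor lies within the scatter) in this assay while the hydroxy group stays in place. This change on a ring carbon therefore brings no lowering of the number, whereas a 14-fold lower number from compound 1 to compound 3 (1.16 log units; beyond the scatter) came with a methyl on the oxygen. How far the number rises cannot be told, since the floor of the step lies within the scatter and compound 4 is known only through a limit of the assay, not a number: the limit of > 200000 nM in this assay, at which 2 of the 4 values shown sit.

From the compounds shown here alone, whether a chlorine atom or an ethyl group on this aromatic carbon would behave as the methyl does remains open. Also open, going by these compounds, is what the same ring methyl would do on compound 3, where the hydroxy group is replaced by a methoxy group and the number is far lower than for compound 1.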